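The source may hold more compounds than are shown below. What is called first, only, known or untested is meant among the compounds shown, and "the series" means these compounds.

In a functional assay for inhibition, with Sus scrofa as the target (on this read-out lower numbers stand for stronger inhibition and higher numbers for weaker inhibition), compound 2 `CC1(C)Oc2ccc(C#N)cc2[C@@H](Oc2ccc(=O)[nH]n2)[C@@]1(O)COC(=O)c1ccccc1` gives > 100000 nM, which is a limit and not a number. Compound 1 `CC1(C)Oc2ccc(C#N)cc2[C@@H](Oc2ccc(=O)[nH]n2)[C@@]1(O)Cc1ccccc1` gives > 100000 nM, likewise a limit. Among the compounds with values here, the only measured step is a step that the two limits leave unreadable from compound 1 to compound 2, so it offers no size to carry forward. Compound 3 `CC1(C)Oc2ccc(C#N)cc2[C@@H](Oc2ccc(=O)[nH]n2)[C@@]1(O)CO` differs from compound 2 by hydrogen in place of benzoyl on an oxygen on a saturated carbon, which amounts to benzoyloxy to hydroxy. Without a readable precedent, only a tentative move toward stronger inhibition is expected, and compound 3 may well remain at the limit. The expected change is an at least 2.5-fold lower number from compound 2 to compound 3 (0.39 log units; beyond the scatter). For compound 3 the estimated value is 40000 nM, with an expected range of 5000 nM to 100000 nM.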

Compound 3, half-maximal inhibitory concentration: 700 nM
Compound 3: middle estimate off by 57-fold (1.76 log units), on the high side, and the stated range ends above it.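

Before compound 3, this position offered no readable size: the limit of > 100000 nM in this assay, at which 2 of the 3 values shown sit. In this assay hydrogen in place of benzoyl on an oxygen on a saturated carbon gives an at least 140-fold lower number from compound 2 to compound 3 (2.15 log units; beyond the scatter), and hydroxy in place of phenyl on a saturated chain carbon bound to a saturated ring carbon gives an at least 140-fold lower number from compound 1 to compound 3 (2.15 log units; beyond the scatter). Of the three compounds, only the hydroxymethyl compound gives a number and not a limit.

Whether the free hydroxy itself is required stays open, as no methoxy or amine at this place is shown. Going by these compounds, whether a longer chain ending in hydroxy holds the result of compound 3 also stays open.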